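Methoxy in Place of Chloro: Paw Edema Inhibition

This account rests on a few compounds, and the source may have more. Where it says the series, first, only, none or still open, it means among the compounds named here.

Compound 1, `CN1C[C@@H](c2ccc(F)cc2)[C@@]2(Cc3ccccc3C2=O)[C@@]12C(=O)Nc1ccccc12`: 21.1%
Compound 2, `CN1C[C@@H](c2ccc(Cl)cc2)[C@@]2(Cc3ccccc3C2=O)[C@@]12C(=O)Nc1ccccc12`: 18.9%

Of the compounds shown here, two have been tested so far. In a functional assay on the whole organism (strain Wister albino) for inhibition, with Rattus norvegicus as the target, read by paw edema, with stated times of 1 h and 3 h, at a dose of 50 mg/kg by the intraperitoneal route (a lower number here means less inhibition, a higher number more inhibition at the dose given (going by the name of the read-out)), compound 1 gives 21.1% and compound 2 gives 18.9%. Going by the values given here, the only step between them, a number 2.2 percentage points lower from compound 1 to compound 2 (within the scatter), is a change of one halogen for another on the same aromatic carbon, and it lies within the scatter of this assay. Compound 2 therefore cannot be set apart from compound 1: its number is the smaller of the two, but the gap is too narrow to read as a real difference.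

Compound 3, `COc1ccc([C@@H]2CN(C)[C@]3(C(=O)Nc4ccccc43)[C@]23Cc2ccccc2C3=O)cc1`, is the next compound to be tested. Compared with compound 2 it shows (methoxy in place of chloro on an aromatic carbon). Among the compounds with values here, no measured step involves a methoxy group, so the one step available, from fluoro to chloro, is the only guide, and it was flat. Given that, the expectation for compound 3 in this assay is a step of about a number 1.1 percentage points higher from compound 2 to compound 3 (within the scatter), which is to say no change beyond the scatter. Compound 3 is estimated at 20%, with a range from 10% to 32%.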

Compound 3, a percentage reported as inhibition, in the whole organism at one dose (the size of the read-out at that dose, not a potency): 20.5%
Estimate against measurement, compound 3: 0.5 percentage points below, and the stated range covers the measured number.
By their numbers in this assay, from the lowest: compounds 2, 3 and 1 (each within the scatter of the next).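

In this assay, putting methoxy in place of chloro gives a number 1.6 percentage points higher from compound 2 to compound 3 (within the scatter), even though two heavy atoms and a hydrogen-bond acceptor enter where one heavy atom with no acceptor stood. Methoxy in place of fluoro gives a number 0.6 percentage points lower from compound 1 to compound 3 (within the scatter), so at this aromatic carbon, para to a large group, a group that is not a halogen now also gives a number that cannot be told apart from those of the two halogens, which the earlier pair could not show. No measurement at hand bears on why these numbers sit so close together.

Still open is whether a group of a different kind at this carbon, such as an amine, a carboxylic acid or a longer chain like butoxy, would give a number beyond the scatter, or whether plain hydrogen there would do the same as the three groups shown. Also open, from the compounds shown here alone, is whether changes elsewhere on the shared core, for example at the amide hydrogen, would move the read-out when this position does not.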